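A few compounds are considered here, and "the series" means these few. Any claim that something is new, unique, unknown or untested is made for them only; others in the source may bear on it.

Working notes on a small indole sulfone series read for agonist response at the serotonin receptor. Compound 1, `O=S(=O)(c1cccc(F)c1)c1cn(C2CCNC2)c2ccc(Cl)cc12`, carries the chloro-substituted core and in a functional assay on HeLa cells for agonist activity at 5-hydroxytryptamine receptor 6 (Homo sapiens), read by cAMP accumulation and immunoassay, with a stated time of 10 min (on this read-out higher numbers stand for larger maximal responses and lower numbers for smaller maximal responses), compound 1 stands as "not determined" (no result reported), with no result reported. Compound 2, `O=S(=O)(c1cccc(F)c1)c1cn(C2CCCNC2)c2ccccc12`, pairs the 3-fluorophenyl sulfone with a six-membered amine ring and gives 78% in this assay. Compound 3, `O=S(=O)(c1cccc(Cl)c1)c1cn(C2CCNC2)c2ccccc12`, pairs the 3-chlorophenyl sulfone with a five-membered amine ring and gives 48% in this assay, the lower of the two numbers at hand and beyond the scatter below compound 2; the two compounds differ in two places at once, so neither change can be singled out.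

Compound 4, `O=S(=O)(c1cccc(F)c1)c1cn(C2CCNC2)c2ccccc12`, differs from compound 3 in one place: fluoro in place of chloro on an aromatic carbon. Within the data shown here, no measured pair isolates this change. Compound 2 does carry the fluoro group and sits high, but its amine ring also differs, so the step in this assay from compound 3 is expected to be small, within or near the scatter, most likely upward. The estimated step is a number 7 percentage points higher from compound 3 to compound 4 (within the scatter). Compound 4 is expected to reach 55%, in a range from 30% to 80%.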

Compound 4, largest response reached (Emax), in percent of the reference or control that the assay uses: 38%
The estimate for compound 4 lay 17 percentage points above the measured number, within the range that was stated.
By their numbers in this assay, from the lowest: compounds 4 and 3 (each within the scatter of the next); then compound 2.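

Chloro and fluoro on this aromatic carbon now form a single-place pair, and the change gives a number 10 percentage points lower from compound 3 to compound 4 (within the scatter) in this assay with no separation between the two halogens on this read-out. The amine ring also has its first single-place pair: pyrrolidin-3-yl in place of piperidin-3-yl on the aromatic nitrogen gives a number 40 percentage points lower from compound 2 to compound 4 (beyond the scatter) on the same read-out, so among these compounds only the amine ring change shifts the maximal response beyond the scatter. No measurement at hand bears on the cause of either step.

As far as these compounds go, whether chloro and fluoro also read alike on the piperidin-3-yl ring stays open, and compound 1 stands at "not determined" (no result reported) so the chloro-substituted core offers no comparison. Also open, from the compounds shown here alone, is how a methoxy group or a nitrile on this aromatic carbon, or an azepane as the amine ring, would read.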